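Shortening the phenoxyalkenyl chain on a weak prostaglandin receptor agonist

The compounds below may be only part of what the source reports. "The series", "measured", "known", "first", "only" and "open" are said of these compounds alone.

The series shares one core, and three of its members have been studied in a functional assay on Chem1 cells for agonist activity at prostaglandin F2-alpha receptor (Homo sapiens), read by fluorescence and calcium flux; a lower number here means that less compound is needed, a higher number that more compound is needed for the effect. Within the data shown here, compound 1 `O=C(O)c1csc([C@H]2CC[C@@H]3[C@@H](/C=C/CCCOc4ccccc4)[C@H](O)C[C@@H]3O2)n1` is the only member with a single number: in this assay compound 1 gives 8500 nM. Compound 2 `O=C(O)c1csc([C@H]2CC[C@@H]3[C@@H](COc4ccccc4)[C@H](O)C[C@@H]3O2)n1` carries a shorter saturated link to the phenoxy group. In this assay compound 2 reaches only a limit, > 10000 nM, and no number beyond that limit is known. Compound 3 `O=C(O)c1csc([C@H]2CC[C@@H]3[C@@H](CCCCCOc4ccccc4)[C@H](O)C[C@@H]3O2)n1` carries a fully saturated five-carbon link; for compound 3 this assay reports "not determined" (no result reported), so it adds nothing to the picture.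

Compound 4 `O=C(O)c1csc([C@H]2CC[C@@H]3[C@@H](/C=C/CCOc4ccccc4)[C@H](O)C[C@@H]3O2)n1` is the next step from compound 1. The change is phenoxy in place of phenoxymethyl on a saturated chain carbon, two bonds along the chain from a double-bonded chain carbon, so the unsaturated chain that ends in the phenoxy group loses one carbon while the double bond and the rest of the core stay in place. No step between two measured compounds is available to weigh this change; what is shown is that compound 1 gives a number and compound 2, with a still shorter link, gives only a limit (the limit of > 10000 nM in this assay, at which 1 of the 3 values shown sits).

The account therefore expects the step from compound 1 to compound 4 to be a weakening, a 1.8-fold higher number from compound 1 to compound 4 (0.25 log units; within the scatter), of modest size. Compound 4 is estimated at 15000 nM, with a plausible range from 5000 nM to 40000 nM, and a real chance that the assay reports only a limit.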

Compound 4, half-maximal effective concentration: 380 nM
Compound 4: the middle estimate sits 39-fold (1.60 log units) above what was measured, outside the stated range (below it).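

Replacing phenoxymethyl with phenoxy on a saturated chain carbon, two bonds along the chain from a double-bonded chain carbon, gives a 22-fold lower number from compound 1 to compound 4 (1.35 log units; beyond the scatter) in this assay. Among these compounds, this is the first step that can be read, and it shows that the activity responds strongly to a change at this position, even though the double bond and the rest of the shared core stay in place. Compound 2 has only a limit, not a number, and its saturated link sets it apart from compound 4 in more than one place, so it cannot show how far the shortening can go: the limit of > 10000 nM in this assay, at which 1 of the 4 values shown sits.

From the compounds shown here alone, it remains open whether an unsaturated chain shorter still would keep the lower number, and whether a sulfur atom or an amine nitrogen in place of the chain oxygen would do the same. The compounds shown also leave the contribution of the double bond unresolved, since no compound here differs from compound 1 or compound 4 in that feature alone with a readable value.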